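Heptyl on the triazole carbon of compound 2

A few compounds are considered here, and "the series" means these few. Any claim that something is new, unique, unknown or untested is made for them only; others in the source may bear on it.

Compound 2 `N#Cc1ccc(Cn2ccnn2)cc1` gives 100 nM in an assay on isolated protein for inhibition of Aromatase (Homo sapiens), read by fluorescence and colorimetric assay, with a stated time of 30 min (on this read-out higher numbers stand for weaker inhibition and lower numbers for stronger inhibition), the lowest of the two numbers recorded. Compound 1 `N#Cc1ccc(C(c2ccc(C#N)cc2)n2cc(COc3ccc(Cl)cc3)nn2)cc1` gives 16100 nM in this assay, a gap that lies beyond the scatter. Compound 3 `CCCCCCCc1cn(Cc2ccc(C#N)cc2)nn1` differs from compound 2 by heptyl in place of hydrogen on an aromatic carbon, a heptyl in place of hydrogen on an aromatic carbon. Going by the values given here, no measured pair shows this change, so the step from compound 2 to compound 3 is expected to be a 3.0-fold higher number from compound 2 to compound 3 (0.48 log units; beyond the scatter), a moderate weakening with wide uncertainty. For compound 3 the estimate in this assay is 300 nM, between 50 nM and 3000 nM.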

Compound 3, half-maximal inhibitory concentration: 3070 nM
Beside the measured number, compound 3's estimate is 10-fold (1.01 log units) below it; the whole stated range lies below it.
By their numbers in this assay, from the lowest: compound 2; then compound 3; then compound 1.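

Going by these compounds alone, on the aromatic carbon of the five-membered aromatic ring with 3 nitrogen, heptyl in place of hydrogen gives a 31-fold higher number from compound 2 to compound 3 (1.49 log units; beyond the scatter) in this assay as the first single-place step. This position is therefore not indifferent to substitution, and heptyl, with no ring, costs inhibition here. Nothing measured accounts for the size of this step.

Going by these compounds, with only heptyl and hydrogen compared at this position, the dependence on chain length remains unknown. A methyl or butyl group, or a chain ending in an amine or carboxylic acid, could separate length from end group.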